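Methoxy added to the aryl ring of compound 1

The compounds below may be only part of what the source reports. "The series", "measured", "known", "first", "only" and "open" are said of these compounds alone.

Measured so far:
compound 1 `CC(=O)OC[C@H]1O[C@H](OC[C@@H](Cn2cc(CN(c3nc(-c4ccccc4)no3)C3CCCCC3)nn2)OC(C)=O)C=C[C@@H]1OC(C)=O`: 19.9 ug/mL
compound 2 `C#CCOc1ccc(-c2noc(N(CC#C)C3CCCCC3)n2)cc1`: > 200 ug/mL

Among the measured compounds shown here, in an ADME assay on HepG2 cells (Homo sapiens) for cytotoxicity, read by MTT assay, with a stated time of 48 h (a higher number here means that more compound is tolerated, a lower number that less compound is tolerated), compound 1 gives 19.9 ug/mL, the only plain number in the set. For compound 2 the read-out is a limit rather than a number, > 200 ug/mL. Compound 3 `COc1ccc(-c2noc(N(Cc3cn(C[C@H](CO[C@@H]4C=C[C@H](OC(C)=O)[C@@H](COC(C)=O)O4)OC(C)=O)nn3)C3CCCCC3)n2)cc1` differs from compound 1 by methoxy in place of hydrogen on an aromatic carbon. For the measured compounds named here, no measured pair isolates this change, so the step of a 1.0-fold higher number from compound 1 to compound 3 (0.00 log units; within the scatter) is expected to stay within the scatter of repeated measurements, with no direction favoured. Compound 3 is therefore estimated at 20 ug/mL, between 8 ug/mL and 50 ug/mL.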

Compound 3, half-maximal cytotoxic concentration: 141 ug/mL
For compound 3 the middle estimate is 7.1-fold (0.85 log units) below the measured one; the whole stated range lies below it.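

The phenyl to 4-methoxyphenyl change is not neutral at this position: in this assay it gives a 7.1-fold higher number from compound 1 to compound 3 (0.85 log units; beyond the scatter), so this aromatic carbon, para to a large group, responds to substitution. Among the compounds shown here, this is the only readable pair, so the finding rests on one change in one background. Compound 2 alone rests on a limit, not a number: the limit of > 200 ug/mL in this assay, at which 1 of the 3 values shown sits.

Going by these compounds, whether the response is specific to methoxy stays open. Fluorine or hydroxyl on the same carbon would test this, as would a longer ether such as ethoxy.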